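Compound 1 and its 1H-indol-3-yl counterpart, compound 4

The compounds below may be only part of what the source reports. "The series", "measured", "known", "first", "only" and "open" are said of these compounds alone.

Measured in an ADME assay on HepG2 cells (Homo sapiens) for cytotoxicity, read by neutral red uptake, with a stated time of 24 h; on this read-out lower numbers stand for stronger inhibition and higher numbers for weaker inhibition:
- Compound 1 `CC(C)c1cc2c3c(c1OC(=O)CCl)OC(=O)[C@@]31CCCC(C)(C)[C@@H]1CC2`: 203000 nM
- Compound 2 `CCCCCCCCCCCCCCCC(=O)Oc1c(C(C)C)cc2c3c1OC(=O)[C@@]31CCCC(C)(C)[C@@H]1CC2`: > 1000000 nM, a limit
- Compound 3 `CCCCC/C=C/C/C=C/CCCCCCCC(=O)Oc1c(C(C)C)cc2c3c1OC(=O)[C@@]31CCCC(C)(C)[C@@H]1CC2`: 289000 nM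

Compound 1 and compound 3 lie within the scatter of each other, so these two numbers set no order. Compound 2 reaches only a limit, > 1000000 nM.

Compound 4 `CC(C)c1cc2c3c(c1OC(=O)Cc1c[nH]c4ccccc14)OC(=O)[C@@]31CCCC(C)(C)[C@@H]1CC2` differs from compound 1 at one place: 1H-indol-3-yl in place of chloro on a saturated chain carbon bound to a carbonyl carbon. Here 1H-indol-3-yl stands in place of chloro on a saturated chain carbon bound to a carbonyl carbon.

For the measured compounds named here, the only measured step is an at least 3.4-fold lower number from compound 2 to compound 3 (0.53 log units; beyond the scatter). That step lies beyond the scatter, but it alters a long chain and involves neither chloro nor 1H-indol-3-yl, so it offers only weak guidance. No step beyond the scatter is therefore expected in this assay, and neither direction is favoured.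

The expected change is a 1.1-fold lower number from compound 1 to compound 4 (0.03 log units; within the scatter).

For compound 4 the estimated value is 190000 nM, with an expected range of 70000 nM to 500000 nM.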

Compound 4, half-maximal inhibitory concentration: 251000 nM
Compound 4: the middle estimate sits 1.3-fold (0.12 log units) below what was measured; low and high end bracket the measured number.
By their numbers in this assay, from the lowest: compounds 1, 4 and 3 (each within the scatter of the next). At a limit, above all of these: compound 2.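

In this assay, the saturated chain carbon bound to a carbonyl carbon accepts a far heavier substituent with no change beyond the scatter: a 1.2-fold higher number from compound 1 to compound 4 (0.09 log units; within the scatter). Chloro, a single heavy atom, gives way to 1H-indol-3-yl, with 9 heavy atoms, a five-membered and a six-membered aromatic ring and 1 hydrogen-bond donor, which is a kind of exchange that the earlier step, confined to a long chain, could not test. Nothing among the data shown accounts for this lack of change.

As far as these compounds go, it remains open whether an amine or a carboxylic acid on the same carbon would also stay within the scatter of compound 1. Also open, from the compounds shown here alone, is whether a phenyl group there would give the same reading as 1H-indol-3-yl.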